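Arylpiperazine indole carboxamides: alpha-adrenergic binding working notes

The source may hold more compounds than are shown below. What is called first, only, known or untested is meant among the compounds shown, and "the series" means these compounds.

Measured compounds:
compound 1 `COc1ccccc1N1CCN(CCCNC(=O)c2ccc3[nH]ccc3c2)CC1`: 26.3 nM
compound 2 `COc1ccc2[nH]c(C(=O)NCCCN3CCN(c4ccccc4OC)CC3)cc2c1`: 77.6 nM
compound 3 `COc1ccccc1N1CCN(CCCNC(=O)c2cc3cccc([N+](=O)[O-])c3[nH]2)CC1`: 58.9 nM

In an assay on isolated protein (Vas deferens, strain Sprague-Dawley) for antagonist activity at Alpha-1A adrenergic receptor (Rattus norvegicus), with a stated time of 20 min (on this read-out lower numbers stand for tighter binding and higher numbers for weaker binding), compound 1 gives 26.3 nM, the lowest of the three numbers. Compound 3 gives 58.9 nM and compound 2 gives 77.6 nM; both stand beyond the scatter from compound 1, so compound 1 is the tightest binder of the measured set in this assay. Among the compounds with values here, compound 2 and compound 3 each carry a different aromatic amide part from compound 1, and both come out with higher numbers, although no measured pair isolates a single change.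

Compound 4 `COc1ccccc1N1CCN(CCCNC(=O)c2cc3ccc(Br)cc3[nH]2)CC1` has not yet been measured in this assay. It differs from compound 1 in one place: 6-bromo-1H-indol-2-yl in place of 1H-indol-5-yl on a carbonyl carbon. Within the data shown here, no measured pair separates this exact exchange, so its size cannot be read off directly. Since both other variations of the aromatic amide part give higher numbers than compound 1, the step is expected to move in the same direction, with a modest loss of binding rather than none: a 1.9-fold higher number from compound 1 to compound 4 (0.28 log units; within the scatter). Compound 4 is accordingly estimated at 50 nM in this assay, with an expected range from 20 nM to 130 nM.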

Compound 4, dissociation constant: 69.2 nM
The estimate for compound 4 lay 1.4-fold (0.14 log units) below the measured number; measured number inside the range.
By their numbers in this assay, from the lowest: compound 1; then compounds 3, 4 and 2 (each within the scatter of the next).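

In this assay, within the data shown here, the exchange of 1H-indol-5-yl for 6-bromo-1H-indol-2-yl on a carbonyl carbon gives the only single-place step, a 2.6-fold higher number from compound 1 to compound 4 (0.42 log units; beyond the scatter), so binding does respond to a change at this place, by a modest amount. The step appears although both groups carry one five-membered aromatic ring with one hetero atom, one six-membered aromatic ring of carbon only, and the same counts of hydrogen-bond donors and acceptors, with bromine as the one added heavy atom. The data available here offer no explanation for the step.

The exchange bundles two differences, the change from 1H-indol-5-yl to an 1H-indol-2-yl group and the presence of bromine, and the compounds shown do not tell how much of the step belongs to each. A plain 1H-indol-2-yl group on the same carbonyl carbon would divide the step between the two, and chlorine or a methoxy group in place of the bromine would show whether the result is particular to bromine.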